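The source may hold more compounds than are shown below. What is called first, only, known or untested is meant among the compounds shown, and "the series" means these compounds.

Measured compounds and their numbers:

Compound 1 `C=C1CC[C@@H]2[C@](C)(CO)[C@H](O)CC[C@@]2(C)[C@@H]1/C=C/C1=C/C(=C/c2ccc(N(C)C)cc2)OC1=O`: 60.6%
Compound 2 `C=C1CC[C@@H]2[C@](C)(COC(=O)c3cccnc3)[C@H](OC(=O)c3cccnc3)CC[C@@]2(C)[C@@H]1/C=C/C1=C/C(=C\c2ccccc2)OC1=O`: 100%
Compound 3 `C=C1CC[C@@H]2[C@](C)(COC(=O)c3cccnc3)[C@H](OC(=O)c3cccnc3)CC[C@@]2(C)[C@@H]1/C=C/C1=C/C(=C\c2ccc(Cl)cc2)OC1=O`: 100%

In an assay on isolated protein for inhibition of Maltase-glucoamylase (Homo sapiens), tested at 100 uM (on this read-out higher numbers stand for more inhibition at the one concentration tested (going by the name of the read-out) and lower numbers for less inhibition), compound 3 gives 100%, level with compound 2 and together with it the highest of the three numbers; compound 1 sits well below both, and that gap lies beyond the scatter. Compound 4 `C=C1CC[C@@H]2[C@](C)(COC(=O)c3cccnc3)[C@H](OC(=O)c3cccnc3)CC[C@@]2(C)[C@@H]1/C=C/C1=C/C(=C\c2ccc(N(C)C)cc2)OC1=O` is not yet measured. It differs from compound 3 in one place: dimethylamino in place of chloro on an aromatic carbon.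

Among the compounds with values here, only one measured step lies close to this change. Swapping hydrogen for chloro on the same aromatic carbon gave no change at the digits printed from compound 2 to compound 3 (within the scatter), so on that position a change of group has so far left the number level. Compound 1 also carries dimethylamino on that ring, but it differs from compound 4 in two further places as well, so its lower number cannot be read as the effect of the dimethylamino group alone.

On this basis, compound 4 is expected to stay near the top: the estimated step is a number 5 percentage points lower from compound 3 to compound 4 (within the scatter), and compound 4 is estimated at 95%, with a range from 78% to 100%.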

Compound 4, a percentage reported as inhibition, at one concentration (the size of the read-out at that concentration, not a potency): 74.8%
Beside the measured number, compound 4's estimate is 20.2 percentage points above it; the measured number lies below the stated range.
By their numbers in this assay, from the lowest: compound 1; then compound 4; then compounds 2 and 3 (each within the scatter of the next).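

In this assay, this carbon on the aromatic ring does not treat every group alike: dimethylamino in place of chloro gives a number 25.2 percentage points lower from compound 3 to compound 4 (beyond the scatter) and dimethylamino in place of hydrogen gives a number 25.2 percentage points lower from compound 2 to compound 4 (beyond the scatter) on the same carbon. The level reading from hydrogen and chloro therefore does not extend to all groups here, and since both of those compounds sit at the top of the percentage scale, that reading could not show any difference beyond it. Nothing shown explains why dimethylamino lowers the number.

Going by these compounds, it remains open whether the lower number goes with the nitrogen of dimethylamino or simply with a group of more atoms than chloro. A plain amino group, a methoxy group or an isopropyl group on the same carbon would help separate these two readings.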